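Trimming an Amine Substituent on a Kinase Inhibitor Scaffold

The source may hold more compounds than are shown below. What is called first, only, known or untested is meant among the compounds shown, and "the series" means these compounds.

Of the compounds shown here, three have so far been tested in an assay on isolated protein for inhibition of tyrosine-protein kinase receptor UFO (Homo sapiens), with a stated time of 1.5 h; a higher number here means a weaker inhibitor, a lower number a stronger inhibitor. Compound 1 `Cc1cnc2[nH]ccc2c1Cl` gives 20200 nM in this assay. Compound 2 `Nc1ccc2c(Br)n[nH]c2c1` reaches only the limit of the measurement: in this assay compound 2 gives > 770000 nM, which is a limit and not a number. Compound 3 `Cn1cc(-c2n[nH]c3ccc(N[C@@H]4CCNC4)cc23)cn1` carries a (pyrrolidin-3-yl)amino group on its core and in this assay gives 37000 nM. Of the two numbers actually read, compound 3 has the higher one, but its nearest neighbour is compound 1, whose value differs by an amount within the usual scatter, so the two cannot be ranked against each other.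

Compound 4 `Cn1cc(-c2n[nH]c3ccc(N)cc23)cn1` has not yet been measured. It differs from compound 3 in one place: hydrogen in place of pyrrolidin-3-yl on a nitrogen on an aromatic ring. The pyrrolidin-3-yl ring, with its hydrogen-bond donor, its hydrogen-bond acceptor and its defined stereocentre, is removed, leaving a bare amino group on the aromatic ring. Among the measured compounds shown here, no measured pair in this set makes the same change, so there is no step to lean on, and the only other compound with a bare amino group, compound 2, gave a limit. The step from compound 3 to compound 4 is therefore expected to go towards a higher number, beyond the scatter, as a 3.2-fold higher number from compound 3 to compound 4 (0.51 log units; beyond the scatter). Compound 4 is estimated to give 120000 nM in this assay, with a likely range from 30000 nM to 500000 nM.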

Compound 4, half-maximal inhibitory concentration: 8910 nM
Estimate against measurement, compound 4: 13-fold (1.13 log units) above, and the stated range ends above it.
By their numbers in this assay, from the lowest: compound 4; then compounds 1 and 3 (each within the scatter of the next). At a limit, above all of these: compound 2.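

In this assay, replacing pyrrolidin-3-yl with hydrogen on the nitrogen on the aromatic ring gives a 4.2-fold lower number from compound 3 to compound 4 (0.62 log units; beyond the scatter). Among the compounds shown here, this is the first measured view of this position, and it shows that the low number does not depend on the (pyrrolidin-3-yl)amino group: the whole ring, with its defined stereocentre, can be removed and the inhibition gets stronger rather than weaker. The data shown offer no measured property that would explain why removing the ring moves the number in this direction, so the step stands as an observation and nothing more.

From the compounds shown here alone, with only the bare amino group and one ring-bearing amine at this position, it remains open whether a small group such as methyl or acetyl on the same nitrogen would lower the number further, or whether an open-chain amine such as 2-aminoethyl would behave like the pyrrolidin-3-yl group. Going by these compounds, it is also open whether the mirror-image form of the pyrrolidin-3-yl group would give a different number, and whether the same change would have a similar effect on another core.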